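From 3,4-difluorophenyl to 3-chlorophenyl on a shared core

The source may hold more compounds than are shown below. What is called first, only, known or untested is meant among the compounds shown, and "the series" means these compounds.

Compound 1 `CC(C)c1ccc(Nc2ccc3c(OCCCN4CCN(C)CC4)cccc3n2)cc1` (19900 nM)
Compound 2 `CN1CCN(CCCOc2cccc3nc(Nc4ccc(F)c(F)c4)ccc23)CC1` (1010 nM)

In a functional assay on NCI-H522 cells (Homo sapiens) for inhibition, read by sulforhodamine B assay, with a stated time of 48 h (on this read-out lower numbers stand for stronger inhibition of growth and higher numbers for weaker inhibition of growth), compound 2 gives the lower of the two numbers (1010 nM), so it inhibits growth more strongly than compound 1. Compound 3 `CN1CCN(CCCOc2cccc3nc(Nc4cccc(Cl)c4)ccc23)CC1` differs from compound 2 in one place (3-chlorophenyl in place of 3,4-difluorophenyl on a nitrogen on an aromatic ring), with 3-chlorophenyl in place of 3,4-difluorophenyl on a nitrogen on an aromatic ring. Among the compounds with values here, one measured step bears on this place, and it was large (a 20-fold lower number from compound 1 to compound 2 (1.29 log units; beyond the scatter)). That step involved a different pair of groups, so it shows that this place can matter but gives no firm direction for the new change. A much smaller change is therefore expected in this assay, perhaps towards a slightly higher number and possibly within the scatter. The expected change is small (a 1.5-fold higher number from compound 2 to compound 3 (0.17 log units; within the scatter)). Compound 3 is estimated at 1500 nM (expected range 500 nM to 4500 nM).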

Compound 3, concentration for 50% growth inhibition: 1480 nM
Compound 3: the middle estimate sits 1.0-fold (0.01 log units) above what was measured, within the range that was stated.
By their numbers in this assay, from the lowest: compounds 2 and 3 (each within the scatter of the next); then compound 1.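

In this assay the change from 3,4-difluorophenyl to 3-chlorophenyl gives a 1.5-fold higher number from compound 2 to compound 3 (0.17 log units; within the scatter) and so leaves the two compounds indistinguishable: this position accepts either of these two groups, despite their different halogens. The large step seen earlier is not tied to the 3,4-difluorophenyl group alone, as 3-chlorophenyl also gives a 13-fold lower number from compound 1 to compound 3 (1.13 log units; beyond the scatter) and thus separates clearly from the 4-isopropylphenyl of compound 1. No supporting measurement explains why these two groups give such similar growth inhibition.

On these data alone, it remains open whether an unsubstituted phenyl, or a phenyl carrying a methoxy group or an amine, would match compound 2 and compound 3 or fall nearer compound 1. Nor do these three compounds show whether a single fluorine or a trifluoromethyl group would be tolerated here.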